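Furan to Thiophene Swap Carried onto a Second Core

A few compounds are considered here, and "the series" means these few. Any claim that something is new, unique, unknown or untested is made for them only; others in the source may bear on it.

Compound 1, `O=C(CCCCCCc1ccccc1)c1ncc(-c2ccco2)s1`, gives > 10000 nM in an assay on HEK-293T cells for inhibition of diacylglycerol lipase-alpha (Homo sapiens), read by colorimetric assay (a lower number here means a stronger inhibitor, a higher number a weaker inhibitor), which is a limit of the assay.
Compound 2, `O=C(CCCCCCc1ccccc1)c1ncc(-c2cccs2)s1`, gives > 10000 nM in this assay, again a limit.
Among the measured compounds shown here, compound 3, `O=C(CCCCCCc1ccccc1)c1nc(-c2ccco2)no1`, gives 933 nM in this assay, the only number among the three.

The change thiophen-2-yl in place of furan-2-yl on an aromatic carbon produced a step that the two limits leave unreadable from compound 1 to compound 2, because of the limit of > 10000 nM in this assay, at which 2 of the 3 values shown sit. How the core of compound 3 differs from the core of compound 1 is not broken down here.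

Compound 4, `O=C(CCCCCCc1ccccc1)c1nc(-c2cccs2)no1`, carries the same kind of change, (thiophen-2-yl in place of furan-2-yl on an aromatic carbon). The surroundings differ: in compound 2 the ring bearing the group holds one nitrogen and one sulfur and the group sits next to the ring sulfur, whereas in compound 4 the ring holds two nitrogen and one oxygen and the group sits between two ring nitrogen atoms.

In this assay compound 4 is expected to give 1000 nM, a step of a 1.1-fold higher number from compound 3 to compound 4 (0.03 log units; within the scatter), since the same kind of change from compound 1 to compound 2 left no readable step and compound 3 already gives 933 nM.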

Compound 4, half-maximal inhibitory concentration: 1950 nM
Estimate against measurement, compound 4: 2.0-fold (0.29 log units) below, within the range that was stated.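

In this assay thiophen-2-yl in place of furan-2-yl on the core of compound 3 gives a 2.1-fold higher number from compound 3 to compound 4 (0.32 log units; beyond the scatter) and so weakens inhibition modestly on this core, while compound 4 still gives a measured number. The same change on the core of compound 1 cannot be read, because both compounds carrying it there sit at a limit of the assay: the limit of > 10000 nM in this assay, at which 2 of the 4 values shown sit. The series thus holds one readable instance of this change, which does not show whether its size or even its direction carries from one core to the other, and which gives no reason for the step.

The compounds shown leave open how the core of compound 3 would respond to other groups at this place, such as an amine, a carboxylic acid or a phenyl ring. They also leave open whether a shorter or longer chain between the carbonyl and the terminal phenyl ring would change the size of the step.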